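The source may hold more compounds than are shown below. What is called first, only, known or untested is meant among the compounds shown, and "the series" means these compounds.

In a functional assay on LS174T cells (Homo sapiens) for inhibition, read by MTT assay, with a stated time of 72 h (a lower number here means a stronger inhibitor, a higher number a weaker inhibitor), compound 1 `CC(C)c1ccc(C(=O)/C=C/C(=O)O)cc1` gives 25700 nM as its value, compound 2 `CCc1ccc(C(C)C)cc1C(=O)/C=C/C(=O)O` gives 5940 nM and compound 3 `CC(C)c1ccc(C(C)C)c(C(=O)/C=C/C(=O)O)c1` gives 6230 nM on the same read-out. Compound 2 and compound 3 sit together at the low end of these numbers, and compound 1 stands clearly higher. Compound 4 `CCc1c(C(=O)/C=C/C(=O)O)cc(C(C)C)cc1C(C)C` follows from compound 2 by one change isopropyl in place of hydrogen on an aromatic carbon in which isopropyl replaces hydrogen on an aromatic carbon, ortho to an ethyl group. Going by the values given here, the one measured step that bears on it is a 1.0-fold higher number from compound 2 to compound 3 (0.02 log units; within the scatter) for a methyl in place of hydrogen on a saturated chain carbon, and that change sits elsewhere on the molecule. Compound 1 and compound 2 differ in more than one place, so their gap does not size this change. Only a modest move towards a lower number in this assay is therefore expected, quite possibly none beyond the scatter. The expected step is a 1.5-fold lower number from compound 2 to compound 4 (0.17 log units; within the scatter) in this estimate. Compound 4 is estimated at 4000 nM with an expected range from 1500 nM to 10000 nM for repeated measurements.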

Compound 4, half-maximal inhibitory concentration: 12400 nM
Estimate against measurement, compound 4: 3.1-fold (0.49 log units) below, outside the stated range (above it).
By their numbers in this assay, from the lowest: compounds 2, 3 and 4 (each within the scatter of the next, the first and the last beyond it); then compound 1.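

In this assay the aromatic carbon ortho to an ethyl group proves responsive to substitution: isopropyl in place of hydrogen there gives a 2.1-fold higher number from compound 2 to compound 4 (0.32 log units; beyond the scatter) and so moves the number upward, a modest loss of inhibition. Going by these compounds alone, the earlier compounds could not show this, since their only single-place step, a 1.0-fold higher number from compound 2 to compound 3 (0.02 log units; within the scatter), concerns a saturated chain carbon elsewhere on the molecule. No measured property of these compounds accounts for the upward move.

From the compounds shown here alone, whether this move belongs to isopropyl itself or to any group at this position stays open, as a fluorine atom, a methoxy group or an amine on the same aromatic carbon could settle. Also open, going by these compounds, is whether the same isopropyl change on compound 3 would give a step of similar size.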